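Aryl variation at the pyrazole carboxylic acid series

A few compounds are considered here, and "the series" means these few. Any claim that something is new, unique, unknown or untested is made for them only; others in the source may bear on it.

Three analogues share one core and differ only in the group on an aromatic carbon of the five-membered ring. In a functional assay on BJAB cells (Homo sapiens) for antiproliferative activity, with a stated time of 4 days (a higher number here means that more compound is needed for the effect, a lower number that less compound is needed), compound 1 `Cc1cc(C)cc(-c2c(C)nn(-c3nc(-c4ccc(Cl)c(Cl)c4)c(SC(C)C)s3)c2C(=O)O)c1` gives 2700 nM, compound 2 `Cc1nn(-c2nc(-c3ccc(Cl)c(Cl)c3)c(SC(C)C)s2)c(C(=O)O)c1-c1cnn(C)c1` gives 6800 nM, and compound 3 `Cc1cc(-c2c(C)nn(-c3nc(-c4ccc(Cl)c(Cl)c4)c(SC(C)C)s3)c2C(=O)O)cc(C)n1` gives 580 nM. Compound 3 stands lowest of the three: a 4.7-fold lower number from compound 1 to compound 3 (0.67 log units; beyond the scatter) and a 12-fold lower number from compound 2 to compound 3 (1.07 log units; beyond the scatter), while a 2.5-fold higher number from compound 1 to compound 2 (0.40 log units; beyond the scatter). Compound 4 `CC(=O)Nc1ccc(-c2c(C)nn(-c3nc(-c4ccc(Cl)c(Cl)c4)c(SC(C)C)s3)c2C(=O)O)cc1` has not yet been measured; the change is 4-acetamidophenyl in place of 2,6-dimethylpyridin-4-yl on an aromatic carbon.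

Both measured steps into compound 3 bear on this, since each swapped the ring that sits at this position, and each was beyond the scatter. Compound 4 returns to a carbon-only six-membered ring, as in compound 1, and carries a new donor and acceptor. A step back toward the number of compound 1 is expected, so that compound 4 is expected to show a 4.3-fold higher number from compound 3 to compound 4 (0.63 log units; beyond the scatter). For compound 4 the estimate in this assay is 2500 nM, with a range from 700 nM to 9000 nM.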

Compound 4, half-maximal effective concentration: 139000 nM
For compound 4 the middle estimate is 56-fold (1.75 log units) below the measured one; measured number above the stated range.
By their numbers in this assay, from the lowest: compound 3; then compound 1; then compound 2; then compound 4.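

In this assay this position proves far less tolerant than the three earlier rings suggested: the change gives a 240-fold higher number from compound 3 to compound 4 (2.38 log units; beyond the scatter) and also a 51-fold higher number from compound 1 to compound 4 (1.71 log units; beyond the scatter) while a 20-fold higher number from compound 2 to compound 4 (1.31 log units; beyond the scatter), so each of these steps is larger than any step among compounds 1, 2 and 3. A carbon-only six-membered ring therefore does not set the number by itself, since compound 1 and compound 4 both carry one and still sit far apart. Nothing available here accounts for the size of these steps.

Going by these compounds, it remains open whether these steps belong to the whole acetamido group or to its nitrogen-hydrogen alone. A 4-aminophenyl or a 4-methoxyphenyl group at this position would help separate the two.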